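A few compounds are considered here, and "the series" means these few. Any claim that something is new, unique, unknown or untested is made for them only; others in the source may bear on it.

Of the compounds shown here, three sharing one core have been tested in an assay for inhibition of Thromboxane-A synthase (Homo sapiens); on this read-out higher numbers stand for weaker inhibition and lower numbers for stronger inhibition. Compound 1 `O=C(O)CCCCCCc1cccc2cncn12` carries a carboxylic acid at the end of its chain and gives 5.2 nM. Compound 2 `CNC(=O)CCCCCc1cccc2cncn12`, with a methyl-bearing amide in place of that acid, gives 270 nM, and compound 3 `O=C(CCCCCc1cccc2cncn12)NO`, with a hydroxy-bearing amide, gives 20 nM. Compound 3 therefore stands second highest of the three numbers: a 3.8-fold higher number from compound 1 to compound 3 (0.59 log units; beyond the scatter), while a 14-fold lower number from compound 2 to compound 3 (1.13 log units; beyond the scatter).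

Compound 4 `C/C(=C\CCCCCc1cccc2cncn12)C(=O)O` is the next step. Its change is 2-carboxyprop-1-en-1-yl in place of hydroxycarbamoyl on a saturated chain carbon, five bonds along the chain from an aromatic carbon. The acid returns, now on a longer, branched and unsaturated chain end. The step bearing most on this is the one from the acid of compound 1 to the amide of compound 3, which was a 3.8-fold higher number from compound 1 to compound 3 (0.59 log units; beyond the scatter); the larger step of a 52-fold higher number from compound 1 to compound 2 (1.72 log units; beyond the scatter) points the same way, an acid at the chain end giving the lowest number seen. For the measured compounds named here, a modest downward step is therefore expected, a 2.9-fold lower number from compound 3 to compound 4 (0.46 log units; beyond the scatter), with no measured compound showing what the altered chain end itself does.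

Compound 4 is estimated at 7 nM, likely between 2 nM and 30 nM.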

Compound 4, half-maximal inhibitory concentration: 19 nM
Estimate against measurement, compound 4: 2.7-fold (0.43 log units) below, and the stated range covers the measured number.
By their numbers in this assay, from the lowest: compound 1; then compounds 4 and 3 (each within the scatter of the next); then compound 2.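

Compound 4 ends in a carboxylic acid, as compound 1 does, yet in this assay an acid on this altered chain end does not match compound 1 (a 3.7-fold higher number from compound 1 to compound 4 (0.56 log units; beyond the scatter)). Swapping the hydroxycarbamoyl group for 2-carboxyprop-1-en-1-yl leaves no readable difference (a 1.1-fold lower number from compound 3 to compound 4 (0.02 log units; within the scatter)), whereas the same group stands well apart from the methyl-bearing amide (a 14-fold lower number from compound 2 to compound 4 (1.15 log units; beyond the scatter)). The compounds shown come with no measurement that explains any of these steps.

From the compounds shown here alone, the 2-carboxyprop-1-en-1-yl group brings the methyl branch and the double bond in a single change, so what each does alone remains open. An unbranched saturated acid of the same length as compound 4, or an ester at the chain end, would help separate these parts.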